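Hydroxy for cyano on the triazole aryl ring

This account rests on a few compounds, and the source may have more. Where it says the series, first, only, none or still open, it means among the compounds named here.

Measured compounds:
- compound 1, `CC1(C)[C@H]2CC[C@]1(C)N(Cc1cn(-c3cccc(C#N)c3)nn1)C(=O)C2`: 260 nM
- compound 2, `CC1(C)[C@H]2CC[C@]1(C)N(Cc1cn(-c3ccc(O)cc3)nn1)C(=O)C2`: 100 nM
- compound 3, `CC1(C)[C@H]2CC[C@]1(C)N(Cc1cn(-c3ccccc3)nn1)C(=O)C2`: 160 nM

Three compounds share one core and differ only in the aryl group on the triazole nitrogen. In a functional assay on PANC-1 cells (Homo sapiens) for inhibition, read by MTT assay, with a stated time of 24 h (a lower number here means a stronger inhibitor, a higher number a weaker inhibitor), compound 1 gives 260 nM, the highest number of the three. Its gap to compound 3 is a 1.6-fold lower number from compound 1 to compound 3 (0.21 log units; within the scatter) and sits within the scatter; its gap to compound 2 is a 2.6-fold lower number from compound 1 to compound 2 (0.41 log units; beyond the scatter) and lies beyond it. Compound 2 against compound 3 reads a 1.6-fold higher number from compound 2 to compound 3 (0.20 log units; within the scatter), within the scatter.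

The next compound is compound 4, `CC1(C)[C@H]2CC[C@]1(C)N(Cc1cn(-c3cccc(O)c3)nn1)C(=O)C2`. Compared with compound 1 the change is hydroxy in place of cyano on an aromatic carbon.

Going by the values given here, two measured steps bear on it. Removing cyano altogether gave a 1.6-fold lower number from compound 1 to compound 3 (0.21 log units; within the scatter), a small move. Swapping cyano for hydroxy, though at a different position on the ring, gave a 2.6-fold lower number from compound 1 to compound 2 (0.41 log units; beyond the scatter), a modest but real drop. Since compound 4 carries hydroxy, a step of similar sign is expected, somewhere between those two, so the estimated step is a 2.0-fold lower number from compound 1 to compound 4 (0.30 log units; within the scatter). Compound 4 is therefore expected at 130 nM, with a range from 60 nM to 280 nM.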

Compound 4, half-maximal inhibitory concentration: 280 nM
For compound 4 the middle estimate is 2.2-fold (0.33 log units) below the measured one; the range from low to high includes it.
By their numbers in this assay, from the lowest: compounds 2, 3, 1 and 4 (each within the scatter of the next, the first and the last beyond it).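

At this place, on an aromatic carbon meta to a large group, hydroxy in place of cyano gives no readable separation in this assay (a 1.1-fold higher number from compound 1 to compound 4 (0.03 log units; within the scatter)), and hydroxy in place of hydrogen also stays within the scatter (a 1.8-fold higher number from compound 3 to compound 4 (0.24 log units; within the scatter)). Hydroxy at this place therefore does not reproduce what the 4-hydroxyphenyl group of compound 2 showed: with 3-hydroxyphenyl in place of 4-hydroxyphenyl, the two compounds separate beyond the scatter (a 2.8-fold higher number from compound 2 to compound 4 (0.45 log units; beyond the scatter)), so in this pair the place of the hydroxy on the ring matters to the number, not merely its presence. No measurement at hand accounts for the gap between these two hydroxyphenyl compounds.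

On these data alone, whether a methoxy group or an amine at either of these places would read like compound 2 or like compound 4 stays open, as does how a 4-cyanophenyl group would compare with the 3-cyanophenyl group of compound 1. Also open, as far as these compounds go, is whether the gap between the two hydroxyphenyl groups would persist with a change to the shared core, which is constant across all four compounds.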